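A few compounds are considered here, and "the series" means these few. Any claim that something is new, unique, unknown or untested is made for them only; others in the source may bear on it.

Among the measured compounds shown here, compound 2 `Cc1cc(O)c(C2=NN(c3ccc(S(N)(=O)=O)cc3)C(/C=C/c3ccccc3)C2)cc1Cl` gives 20200 nM in a functional assay on OVCAR-8 cells (Homo sapiens) for antiproliferative activity, with a stated time of 48 h; a higher number here means a weaker inhibitor of growth, a lower number a stronger inhibitor of growth; of the two numbers recorded it stands at the top, with compound 1 `Cc1cc(O)c(C2=NN(c3ccc(S(N)(=O)=O)cc3)C(c3ccccc3Cl)C2)cc1Cl` as its only neighbour. In this assay compound 1 gives 11200 nM, and the step of a 1.8-fold higher number from compound 1 to compound 2 (0.26 log units; within the scatter) lies within the scatter, so the two compounds cannot be told apart. Compound 3 `COc1ccc(C2CC(c3cc(Cl)c(C)cc3O)=NN2c2ccc(S(N)(=O)=O)cc2)cc1OC` has not yet been measured. It differs from compound 2 by 3,4-dimethoxyphenyl in place of 2-phenylethenyl on a saturated ring carbon. For the measured compounds named here, the single measured step that bears on this change is the earlier swap on that saturated ring carbon, a 1.8-fold higher number from compound 1 to compound 2 (0.26 log units; within the scatter), which was small. Going by the values given here, with only one such exchange known, and that one inside the scatter, no step beyond the scatter is expected in this assay for the new exchange either. Compound 3 is therefore estimated to give about 15000 nM, within a range from 5000 nM to 45000 nM, an expected step of a 1.3-fold lower number from compound 2 to compound 3 (0.13 log units; within the scatter).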

Compound 3, concentration for total growth inhibition: 17900 nM
Estimate against measurement, compound 3: 1.2-fold (0.08 log units) below; the measured number falls inside the stated range.
By their numbers in this assay, from the lowest: compounds 1, 3 and 2 (each within the scatter of the next).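

With a 1.1-fold lower number from compound 2 to compound 3 (0.05 log units; within the scatter) and a 1.6-fold higher number from compound 1 to compound 3 (0.20 log units; within the scatter) in this assay on the saturated ring carbon next to the ring nitrogen, 3,4-dimethoxyphenyl cannot be told apart from either 2-phenylethenyl or 2-chlorophenyl. This position now holds three different groups without a step beyond the scatter, and 3,4-dimethoxyphenyl, the only one of the three with oxygen and with hydrogen-bond acceptors, brings no measurable separation from the other two. Nothing measured here accounts for this result. Going by these compounds, the three groups all carry a six-membered aromatic ring of carbon only, so whether an amine, a carboxylic acid or a longer alkyl chain on this carbon would give a step beyond the scatter stays open. Also open, on these data alone, is whether replacing the 4-sulfamoylphenyl group would give such a step.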